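The source may hold more compounds than are shown below. What is called first, only, known or untested is meant among the compounds shown, and "the series" means these compounds.

Compound 2 `Cc1noc(C)c1-c1nn(Cc2ccc(C(=O)NC3CC(C)(C)N([O])C(C)(C)C3)cc2)c(=O)c2ccccc12` carries a 3,5-dimethyl-1,2-oxazol-4-yl group on its shared core and an amide bearing a piperidine ring with an oxygen radical on its nitrogen. Within the data shown here, in a functional assay on HCT-116 cells (Homo sapiens) for antiproliferative activity, read by MTT assay, with a stated time of 72 h (a lower number here means a stronger inhibitor, a higher number a weaker inhibitor), compound 2 gives 36800 nM, which is the second highest of the three numbers known. The closest neighbour is compound 3 `Cc1noc(C)c1-c1nn(Cc2ccc(C(=O)NC3CCN(C)CC3)cc2)c(=O)c2ccccc12`, which in this assay gives 84900 nM; the step of a 2.3-fold higher number from compound 2 to compound 3 (0.36 log units; beyond the scatter) concerns only the amide substituent. Further away is compound 1 `Cn1cc(-c2nn(Cc3ccc(C(=O)NC4CCCC4)cc3)c(=O)c3ccccc23)cn1`, which carries a 1-methyl-1H-pyrazol-4-yl group together with a cyclopentyl amide and in this assay gives 14300 nM; it differs from compound 2 in two places, so its lower number cannot be assigned to either change alone.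

Compound 4 `Cn1cc(-c2nn(Cc3ccc(C(=O)NC4CC(C)(C)N([O])C(C)(C)C4)cc3)c(=O)c3ccccc23)cn1` is the one not yet measured. It differs from compound 2 by 1-methyl-1H-pyrazol-4-yl in place of 3,5-dimethyl-1,2-oxazol-4-yl on an aromatic carbon. Among the measured compounds shown here, no measured step isolates this exchange: the only single-point step known, from compound 2 to compound 3, touches the amide rather than the five-membered ring. The values of compound 1 and compound 2 together hint at a lower number with the pyrazole, but the amide difference clouds that. Compound 4 is therefore expected to show a small decrease, a 1.5-fold lower number from compound 2 to compound 4 (0.17 log units; within the scatter), and is estimated at 25000 nM, within a range from 10000 nM to 60000 nM.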

Compound 4, half-maximal inhibitory concentration: 50500 nM
For compound 4 the middle estimate is 2.0-fold (0.31 log units) below the measured one; low and high end bracket the measured number.
By their numbers in this assay, from the lowest: compound 1; then compounds 2, 4 and 3 (each within the scatter of the next, the first and the last beyond it).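

In this assay, putting 1-methyl-1H-pyrazol-4-yl in place of 3,5-dimethyl-1,2-oxazol-4-yl on this aromatic carbon, with the amide bearing the oxygen-radical piperidine held fixed, gives a 1.4-fold higher number from compound 2 to compound 4 (0.14 log units; within the scatter), so on this amide the two five-membered rings cannot be told apart. Among these compounds, with 1-methyl-1H-pyrazol-4-yl held fixed, exchanging the cyclopentyl group on the amide nitrogen for the oxygen-radical piperidine gives a 3.5-fold higher number from compound 1 to compound 4 (0.55 log units; beyond the scatter), a step beyond the scatter that isolates a change at the amide, which the two-place difference between the earlier compounds could not do. Nothing among the available data accounts for either step.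

Among the compounds shown here, whether the ring exchange would read the same on the cyclopentyl amide or the 1-methylpiperidine amide remains open, since the single comparison here rests on one amide. Also open, on these data alone, is what a different group on this aromatic carbon, such as a plain phenyl ring or a carboxylic acid, would give. The compounds shown carry only these two five-membered rings there.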